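The source may report more compounds than this note shows. Statements on the series, on what has been measured and on what is new or still open speak of the compounds shown alone.

In a physicochemical assay for acid dissociation, compound 1 `C#CC(C)OC[n+]1ccn(C)c1/C=N/O` gives 7.96 and compound 2 `C#CC(CC)OC[n+]1ccn(C)c1/C=N/O` gives 7.99, so the two stand level within the usual scatter. Compound 3 `C#CC(CCC)OC[n+]1ccn(C)c1/C=N/O` is still unmeasured. It differs from compound 2 by methyl in place of hydrogen on a saturated chain carbon, three bonds along the chain from an oxygen on a saturated carbon and a triple-bonded carbon. For the measured compounds named here, the one measured step that bears on this is the same replacement two bonds along the chain, and it was small: a number 0.03 log units higher from compound 1 to compound 2 (within the scatter). No change beyond the scatter is therefore expected in this assay. The estimated step is a number 0.01 log units higher from compound 2 to compound 3 (within the scatter). Compound 3 is expected at 8, within an estimated range of 7.8 to 8.2.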

Compound 3, acid dissociation constant: 8.02
For compound 3 the middle estimate is 0.02 log units below the measured one; the measured number falls inside the stated range.
By their numbers in this assay, from the lowest: compounds 1, 2 and 3 (each within the scatter of the next).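

In this assay, the step from ethyl to propyl gives a number 0.03 log units higher from compound 2 to compound 3 (within the scatter), so methyl in place of hydrogen three bonds along the chain leaves the number as level as the same replacement did two bonds along. The larger replacement, ethyl in place of hydrogen two bonds along the chain, gives a number 0.06 log units higher from compound 1 to compound 3 (within the scatter), so the two small steps together still stay inside the scatter. No available measurement offers a cause for this. The compounds shown leave open whether a longer chain, an amine or a carboxylic acid at this position would move the number beyond the scatter.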